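Extending the glycine unit of compound 3 toward compound 4

The source may report more compounds than this note shows. Statements on the series, on what has been measured and on what is new or still open speak of the compounds shown alone.

Compounds measured so far:
- compound 1, `C[C@@H](O)[C@H](NC(=O)CN(c1nc(Cl)nc2[nH]cnc12)C1CC1)C(=O)O`: 37.6%
- compound 2, `CC(C)[C@H](NC(=O)CN(c1ncnc2c1ncn2C1CCCCO1)C1CC1)C(=O)OCc1ccccc1`: 25.8%
- compound 3, `O=C(CN(c1nc(Cl)nc2[nH]cnc12)C1CC1)NCC(=O)OCc1ccccc1`: 21.7%

Three compounds have been run in a functional assay on the whole organism (Tail, strain ICR) with Mus musculus as the target, in the tail flick test, with a stated time of 120 min, at a dose of 25 umol/kg by the oral route; on this read-out higher numbers stand for a stronger effect at the one dose given and lower numbers for a weaker effect. Compound 1 gives 37.6%, compound 2 gives 25.8%, and compound 3 gives 21.7%. Compound 3 holds the lowest number of the three. Its nearest neighbour is compound 2, whose number lies within the scatter of repeated measurements, so the two cannot be told apart on this read-out. Compound 1 stands beyond the scatter above compound 3, the one gap among these three that is clearly resolved. Going by the values given here, none of these pairs differs in a single place, so no step between them can be read directly.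

Compound 4, `NC(=O)CC[C@H](NC(=O)CN(c1nc(Cl)nc2[nH]cnc12)C1CC1)C(=O)OCc1ccccc1`, is not yet measured. It differs from compound 3 in one place: 2-carbamoylethyl in place of hydrogen on a saturated chain carbon bound to an amide-type nitrogen and a carbonyl carbon. Compound 3 carries no group at that carbon, and the change adds a chain of five heavy atoms with one hydrogen-bond donor and one hydrogen-bond acceptor.

Among the compounds with values here, with no single-point step on record, the size of the change can only be estimated. A small rise is expected, a number 6.3 percentage points higher from compound 3 to compound 4 (within the scatter), a step that may not clear the scatter. Compound 4 is estimated at 28%, with a range from 12% to 44%.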

Compound 4, a percentage reported as activity, at one dose (the size of the read-out at that dose, not a potency): 36%
Compound 4: middle estimate off by 8 percentage points, on the low side; measured number inside the range.
By their numbers in this assay, from the lowest: compounds 3 and 2 (each within the scatter of the next); then compounds 4 and 1 (each within the scatter of the next).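

In this assay, going by these compounds alone, 2-carbamoylethyl in place of hydrogen on a saturated chain carbon bound to an amide-type nitrogen and a carbonyl carbon gives a number 14.3 percentage points higher from compound 3 to compound 4 (beyond the scatter), the first step in these compounds that can be read at a single place. It shows that this carbon, which carries no group in compound 3, accepts a chain of five heavy atoms with no loss of effect at the one dose given, and that the change moves the read-out by more than the usual scatter. Nothing on hand bears on why the number moves with this group.

It stays open whether the step belongs to the carbamoyl group itself or to any chain at that carbon, a question that a methyl group, a carboxylic acid or an amine at the same place could help to settle, and none of these stands among the compounds shown. One step at a single dose and a single time also leaves open whether the same change would give a similar step on the core of compound 2.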